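A few compounds are considered here, and "the series" means these few. Any claim that something is new, unique, unknown or untested is made for them only; others in the source may bear on it.

Compound 1 `O=C(COc1ccc(C(=O)/C=C/c2ccccc2Cl)cc1)N[C@H]1CCOC1=O`: in a functional assay on PC-3 cells (Homo sapiens) for antiproliferative activity, read by MTT assay, with a stated time of 72 h (on this read-out lower numbers stand for stronger inhibition and higher numbers for weaker inhibition), compound 1 gives 4610 nM.
Compound 2 `O=C(COc1ccc(C(=O)/C=C/c2ccccc2Br)cc1)N[C@H]1CCOC1=O`: in this assay compound 2 gives 3260 nM.
Compound 3 `O=C(COc1ccc(C(=O)/C=C/c2ccc(Br)cc2)cc1)N[C@H]1CCOC1=O`: in this assay compound 3 reaches only the limit > 64000 nM, not a number.

Compound 3 thus sits at the limit of > 64000 nM in this assay, at which 1 of the 3 values shown sits, the one entry of the three without a measured number. The change to compound 4 `O=C(COc1ccc(C(=O)/C=C/c2cccc(F)c2)cc1)N[C@H]1CCOC1=O` is 3-fluorophenyl in place of 4-bromophenyl on a double-bonded chain carbon bound to a double-bonded chain carbon. For the measured compounds named here, no measured pair keeps the halogen and alters only its ring position. Going by the values given here, the steps that bear on it are an at least 13-fold higher number from compound 1 to compound 3 (1.14 log units; beyond the scatter) and an at least 19-fold higher number from compound 2 to compound 3 (1.29 log units; beyond the scatter), both large rises on going from 2-chlorophenyl or 2-bromophenyl to 4-bromophenyl, while a 1.4-fold lower number from compound 1 to compound 2 (0.15 log units; within the scatter) shows bromo against chloro to matter little. Leaving 4-bromophenyl for 3-fluorophenyl is therefore expected to lower the number, though by how much is open. Compound 4 is estimated at 20000 nM, between 5000 nM and 80000 nM, an expected at least 3.2-fold lower number from compound 3 to compound 4 (0.50 log units; beyond the scatter).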

Compound 4, half-maximal inhibitory concentration: 23200 nM
Estimate against measurement, compound 4: 1.2-fold (0.06 log units) below; the measured number falls inside the stated range.
By their numbers in this assay, from the lowest: compounds 2 and 1 (each within the scatter of the next); then compound 4. At a limit, above all of these: compound 3.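

Going from 4-bromophenyl to 3-fluorophenyl on this double-bonded chain carbon gives an at least 2.7-fold lower number from compound 3 to compound 4 (0.44 log units; beyond the scatter) and brings a measured number back to this place. Compound 3 is only a limit, so that step is a bound: the limit of > 64000 nM in this assay, at which 1 of the 4 values shown sits. The 3-fluorophenyl group still falls short of the two halophenyl groups measured earlier, with a 7.1-fold higher number from compound 2 to compound 4 (0.85 log units; beyond the scatter) and a 5.0-fold higher number from compound 1 to compound 4 (0.70 log units; beyond the scatter) in the series.

Halogen and ring position change together in these steps, so their separate shares stay open. Also open, going by these compounds, is how 3-bromophenyl, or a phenyl carrying an amine or a carboxylic acid, would read here.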